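The source may hold more compounds than are shown below. What is called first, only, known or untested is meant among the compounds shown, and "the series" means these compounds.

In a functional assay for antagonist activity at C-X-C chemokine receptor type 3 (Homo sapiens) (on this read-out lower numbers stand for stronger inhibition and higher numbers for weaker inhibition), compound 3 `CNC(=O)c1cnc(N2CCN(C3CCN(Cc4ccc[nH]4)CC3)[C@@H](C)C2)c(Cl)c1` gives 8060 nM, the highest number of the three measured compounds and so the weakest inhibition. Compound 2 `CNC(=O)c1cnc(N2CCN(C3CCN(Cc4cccs4)CC3)[C@@H](C)C2)c(Cl)c1` gives 1980 nM. Compound 1 `CNC(=O)c1cnc(N2CCN(C3CCN(Cc4ccc(Cl)cc4)CC3)[C@@H](C)C2)c(Cl)c1` gives 32 nM. All steps among them lie beyond the scatter: a 62-fold higher number from compound 1 to compound 2 (1.79 log units; beyond the scatter), a 250-fold higher number from compound 1 to compound 3 (2.40 log units; beyond the scatter) and a 4.1-fold higher number from compound 2 to compound 3 (0.61 log units; beyond the scatter). Compound 4 `CNC(=O)c1cnc(N2CCN(C3CCN(Cc4ccc(C)cc4)CC3)[C@@H](C)C2)c(Cl)c1` has not yet been measured. It differs from compound 3 in one place: 4-methylphenyl in place of 1H-pyrrol-2-yl on a saturated chain carbon bound to an amine nitrogen in a ring. The step that bears most directly on this change is a 250-fold higher number from compound 1 to compound 3 (2.40 log units; beyond the scatter); read in reverse, it swaps the same five-membered ring with one nitrogen for a six-membered ring of carbon only at the same place and points to a large fall in the number. The step of a 4.1-fold higher number from compound 2 to compound 3 (0.61 log units; beyond the scatter) adds that the five-membered ring with one nitrogen gives the highest number in this set. For the measured compounds named here, compound 4 bears 4-methylphenyl where compound 1 bears 4-chlorophenyl, and no measured pair shows that swap, so the exact size of the fall is less certain. A large drop is nonetheless expected, a 160-fold lower number from compound 3 to compound 4 (2.21 log units; beyond the scatter). Compound 4 is therefore estimated at 50 nM, with a range from 15 nM to 200 nM.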

Compound 4, half-maximal inhibitory concentration: 87 nM
Compound 4: the middle estimate sits 1.7-fold (0.24 log units) below what was measured; low and high end bracket the measured number.
By their numbers in this assay, from the lowest: compound 1; then compound 4; then compound 2; then compound 3.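

In this assay, 4-methylphenyl on a saturated chain carbon bound to an amine nitrogen in a ring gives much stronger inhibition than either five-membered ring, with a 93-fold lower number from compound 3 to compound 4 (1.97 log units; beyond the scatter) and a 23-fold lower number from compound 2 to compound 4 (1.36 log units; beyond the scatter), so a low number at this place does not depend on the chloro group of compound 1. Among these four compounds, both with a substituted six-membered ring of carbon only have lower numbers than both with a five-membered ring, and no compound shown goes against this. The group on that ring still counts, though on a smaller scale: methyl in place of chloro on an aromatic carbon gives a 2.7-fold higher number from compound 1 to compound 4 (0.43 log units; beyond the scatter), a modest step that lies beyond the scatter.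

The ring and its substituent change together in these steps. Plain phenyl and 5-chlorothiophen-2-yl would be needed to tell how much of the large steps belongs to the ring itself and how much to the group it carries, and a methoxy or trifluoromethyl group in place of methyl would show how far the number moves with that group. Nothing measured here explains why these groups differ.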